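A few compounds are considered here, and "the series" means these few. Any claim that something is new, unique, unknown or untested is made for them only; others in the source may bear on it.

In an ADME assay on H1-HeLa cells (Homo sapiens) for cytotoxicity, read by MTT assay, with a stated time of 3 days (on this read-out lower numbers stand for higher toxicity in this test and higher numbers for lower toxicity in this test), three compounds have values. Compound 1 `CCOC(=O)c1sc2cc(Oc3cccc(C(=O)NC)c3)ccc2c1C` gives 5100 nM, compound 2 `CNC(=O)c1cc(Oc2ccc3ccc(C(=O)OC)cc3c2)ccn1` gives 53500 nM, and compound 3 `CNC(=O)c1cc(Oc2ccc3ccc(C(=O)OC(C)C)cc3c2)ccn1` gives 13800 nM, which puts compound 3 in the middle of the three. Compound 4 `CNC(=O)c1cc(Oc2ccc3ccc(C(=O)Oc4ccccc4)cc3c2)ccn1` has not been measured. It keeps the core of compound 3 and alters one group: phenyl in place of isopropyl on an oxygen next to a carbonyl group.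

Among the measured compounds shown here, one measured step bears on this change, at the same place: a 3.9-fold lower number from compound 2 to compound 3 (0.59 log units; beyond the scatter), with isopropyl in place of methyl. That step is modest but beyond the usual scatter. For the measured compounds named here, it is only a single step, and no compound with phenyl at this place has been measured, so it suggests a direction and no firm rule. Phenyl has more heavy atoms than isopropyl, so a further, somewhat smaller move towards a lower number is expected. The expected change is a 2.0-fold lower number from compound 3 to compound 4 (0.29 log units; within the scatter). For compound 4 the estimated value is 7000 nM, with a range from 2500 nM to 20000 nM.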

Compound 4, half-maximal cytotoxic concentration: > 100000 nM
Compound 4 ended at the assay's limit; the forecaster's own chance of this, stated with the estimate: 8%; middle value at least 14-fold (1.15 log units) away from the limit.
By their numbers in this assay, from the lowest: compound 1; then compound 3; then compound 2. At a limit, above all of these: compound 4.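

Adding carbon at this place does not move the number in one direction: a 3.9-fold lower number from compound 2 to compound 3 (0.59 log units; beyond the scatter) with isopropyl, but an at least 7.2-fold higher number from compound 3 to compound 4 (0.86 log units; beyond the scatter) with phenyl, so the count of heavy atoms alone does not order compounds 2, 3 and 4. Against the methyl compound the reading is less firm: an at least 1.8-fold higher number from compound 2 to compound 4 (0.27 log units; that floor lies within the scatter), so that floor by itself does not separate the two. In this assay compound 4 gives > 100000 nM, which is a limit of the assay and not a number: the limit of > 100000 nM in this assay, at which 1 of the 4 values shown sits.

Only one compound with a ring at this place is shown, so it remains open whether cyclohexyl or benzyl on the same oxygen would read like phenyl or like isopropyl. A carboxylic acid or an amide in place of this whole group is also left open.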